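Adding a methyl to the best aryl sulfonamide

The source may hold more compounds than are shown below. What is called first, only, known or untested is meant among the compounds shown, and "the series" means these compounds.

compound 1 `O=C(/C=C/c1cccnc1)NCCCc1ccc(S(=O)(=O)Nc2ccccc2)cc1` gives 4120 nM
compound 2 `O=C(/C=C/c1cccnc1)NCCCCCCc1ccc(S(=O)(=O)Nc2ccccc2)cc1` gives 36 nM
compound 3 `Cc1ccc(NS(=O)(=O)c2cccc(CCCCCCNC(=O)/C=C/c3cccnc3)c2)cc1` gives 1.97 nM

These three numbers come from a functional assay on MCF7 cells (Homo sapiens) for inhibition, read by CCK-8 assay, with a stated time of 72 h (a lower number here means a stronger inhibitor, a higher number a weaker inhibitor), and compound 3 has the lowest of them. That makes compound 3 the strongest inhibitor of the three, and its gaps to compound 2 and to compound 1 both lie well beyond the usual scatter of repeated measurements.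

The next compound to be tested is compound 4 `Cc1ccc(C)c(NS(=O)(=O)c2cccc(CCCCCCNC(=O)/C=C/c3cccnc3)c2)c1` which carries 2,5-dimethylphenyl in place of 4-methylphenyl on a sulfonamide nitrogen. The rest of the molecule stays the same. Going by the values given here, no two measured compounds differ in only one place, so the data offer no direct guide to what a change at this place does. Any forecast is therefore loose. Among the compounds with values here, compound 3 already stands at 1.97 nM as the lowest number so far, so a move toward a higher number seems more likely than a further drop, though the change may not clear the scatter. The expected shift is an estimated 2.0-fold higher number from compound 3 to compound 4 (0.31 log units; beyond the scatter) in this assay for this swap. Compound 4 is expected at 4 nM within an estimated range of 1 nM to 16 nM when measured.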

Compound 4, half-maximal inhibitory concentration: 0.6 nM
Compound 4: middle estimate off by 6.7-fold (0.82 log units), on the high side; measured number below the stated range.
By their numbers in this assay, from the lowest: compound 4; then compound 3; then compound 2; then compound 1.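

In this assay, the swap on a sulfonamide nitrogen gives a 3.3-fold lower number from compound 3 to compound 4 (0.52 log units; beyond the scatter), a modest step but one that lies beyond the usual scatter. Going by these compounds alone, compound 3 and compound 4 are the first pair here that differ in only one place, and they show that the aryl group on this nitrogen still moves the number, even from an already low starting value. Both groups are a six-membered aromatic ring of carbon only, with no hydrogen-bond donors, no hydrogen-bond acceptors and no net charge, so they differ only in their methyl groups, and nothing shown here explains why this swap lowers the number.

From the compounds shown here alone, it remains open whether either methyl of 2,5-dimethylphenyl alone would give the same number as compound 4, or whether the pair is needed. Going by these compounds, it is also open how a methoxy group, a chlorine or a trifluoromethyl group on this phenyl ring would compare, and whether a longer chain would keep the number this low.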